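The source may report more compounds than this note shows. Statements on the series, on what has been measured and on what is new or still open speak of the compounds shown alone.

Compound 3 `Cc1cc(OCc2c(-c3[nH]c(=O)ccc3Cl)noc2C(C)C)ccc1-c1ccc2c(C(=O)O)cn(C)c2c1` gives the highest number of the three measured compounds in a functional assay for agonist activity at Bile acid receptor (Mus musculus), read by a luciferase reporter (a higher number here means that more compound is needed for the effect, a lower number that less compound is needed), with 18000 nM. Compound 1 `Cc1cc(OCc2c(-c3cc[nH]c(=O)c3Cl)noc2C(C)C)ccc1-c1ccc2c(C(=O)O)cn(C)c2c1` gives 7000 nM, and compound 2 `COc1ccc(Cl)c(-c2noc(C(C)C)c2COc2ccc(-c3ccc4c(C(=O)O)cn(C)c4c3)c(C)c2)n1` gives 2000 nM. The change from compound 3 to compound 4 `Cc1cc(OCc2c(-c3ccn(C)c(=O)c3Cl)noc2C(C)C)ccc1-c1ccc2c(C(=O)O)cn(C)c2c1` is a group of 9 heavy atoms (6 carbon, 1 nitrogen, 1 oxygen, 1 chlorine; one six-membered aromatic ring with 1 hetero atom) in place of a group of 8 heavy atoms (5 carbon, 1 nitrogen, 1 oxygen, 1 chlorine; one six-membered aromatic ring with 1 hetero atom), on an aromatic carbon. Among the compounds with values here, two measured steps bear on it. From compound 3 back to compound 1 the number falls, as the step of a 2.6-fold higher number from compound 1 to compound 3 (0.41 log units; beyond the scatter) shows in reverse, and compound 4 carries the same ring as compound 1 with a methyl on the ring nitrogen in place of the donor hydrogen. The step of a 9.0-fold higher number from compound 2 to compound 3 (0.95 log units; beyond the scatter) shows that capping the donor of this ring with a methyl on oxygen brings the number down further. Compound 4 is therefore expected to land well below compound 3, with the step of a 5.1-fold lower number from compound 3 to compound 4 (0.71 log units; beyond the scatter) estimated. The estimate for compound 4 in this assay is 3500 nM, with a range from 1200 nM to 10000 nM.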

Compound 4, half-maximal effective concentration: 6000 nM
Compound 4: middle estimate off by 1.7-fold (0.23 log units), on the low side; measured number inside the range.
By their numbers in this assay, from the lowest: compound 2; then compounds 4 and 1 (each within the scatter of the next); then compound 3.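

Putting methyl in place of hydrogen on the ring nitrogen gives a 1.2-fold lower number from compound 1 to compound 4 (0.07 log units; within the scatter) in this assay, so at this position the ring of compound 1 keeps its number without its hydrogen-bond donor. The step of a 3.0-fold lower number from compound 3 to compound 4 (0.48 log units; beyond the scatter) is thus no effect of the methyl seen alone: it matches in size the step of a 2.6-fold higher number from compound 1 to compound 3 (0.41 log units; beyond the scatter), which involves no methyl and only a different arrangement of the same ring atoms. The step of a 3.0-fold higher number from compound 2 to compound 4 (0.48 log units; beyond the scatter) also shows that a methyl on the ring nitrogen does not bring the number to the level of compound 2, whose methyl sits on oxygen in a differently arranged ring. From the compounds shown here alone, whether an ethyl group on that ring nitrogen, or fluorine in place of the ring chlorine, would move the number remains open. Nothing given here explains these differences.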